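Swapping the side group of compound 2

The compounds below may be only part of what the source reports. "The series", "measured", "known", "first", "only" and "open" are said of these compounds alone.

- compound 1 `C[Se]c1ccc(N(C)c2nc(C3CC3)nc3ccccc23)cc1`: 11 nM
- compound 2 `COc1ccc(N(C)c2nc(C)nc3ccccc23)cc1OCCCCCC[Se]C#N`: 8580 nM
- compound 3 `Cc1nc(N(C)c2ccc([Se]C#N)c(C)c2)c2ccccc2n1`: 19 nM

All three values come from a functional assay on LoVo cells (Homo sapiens) for inhibition, read by MTT assay, with a stated time of 48 h; on this read-out lower numbers stand for stronger inhibition and higher numbers for weaker inhibition. Compound 2, at 8580 nM, stands highest of the three, and its gaps to compound 3 and compound 1 both lie beyond the scatter.

Compound 4 `COc1ccc(N(C)c2nc(C)nc3ccccc23)cc1C(=O)NCC[Se]C#N` is the next compound to be read in this assay. The change from compound 2 is a group of 8 heavy atoms (4 carbon, 2 nitrogen, 1 oxygen, 1 selenium; no ring) in place of a group of 10 heavy atoms (7 carbon, 1 nitrogen, 1 oxygen, 1 selenium; no ring), on an aromatic carbon. The new group sits ortho to a methoxy group and meta to a large group. Among the measured compounds shown here, no measured pair differs in one place, so the size of this step has no direct precedent. A step toward a lower number, beyond the scatter, is expected, though one much smaller than the gap down to compound 3 at 19 nM. The expected step is a 2.9-fold lower number from compound 2 to compound 4 (0.46 log units; beyond the scatter). For compound 4 the estimated value is 3000 nM, with an expected range of 500 nM to 15000 nM.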

Compound 4, half-maximal inhibitory concentration: 561 nM
Beside the measured number, compound 4's estimate is 5.3-fold (0.73 log units) above it; the measured number falls inside the stated range.
By their numbers in this assay, from the lowest: compounds 1 and 3 (each within the scatter of the next); then compound 4; then compound 2.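

In this assay, the aromatic carbon ortho to a methoxy group is shown to be sensitive to the group it carries: a 15-fold lower number from compound 2 to compound 4 (1.18 log units; beyond the scatter) accompanies the exchange of one selenium-bearing nitrile group without a ring for another. The entering group has a carbonyl and one hydrogen-bond donor, where the leaving group has no donor, and it has fewer heavy atoms, so several features change in this single step. Nothing available accounts for the size of this step.

The pair leaves open whether the step follows the amide or the shorter group, as the two change together. A longer chain on the same carbonyl, or an ether-linked chain of the same length as in compound 4, would separate these two features.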